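The compounds below may be only part of what the source reports. "The series", "measured", "known", "first", "only" and "open" are said of these compounds alone.

Measured compounds:
compound 1 `CCOC(=O)c1ccc(NC(=O)NCc2cc[nH]n2)cc1` with 69000 nM
compound 2 `CN(Cc1ccccc1)S(=O)(=O)c1ccc(NC(=O)NCc2ccncc2)cc1` with 23 nM
compound 3 `CCOC(=O)c1ccc(NC(=O)OCc2ccncc2)cc1` with 10800 nM

In an assay on isolated protein for activation of Nicotinamide phosphoribosyltransferase (Homo sapiens) (on this read-out lower numbers stand for an effect already at smaller amounts and higher numbers for an effect only at larger amounts of compound), compound 2 gives the lowest of the three numbers; compound 3 and compound 1 both give higher numbers, and each of those gaps lies beyond the usual scatter. Compound 4 `NS(=O)(=O)c1ccc(NC(=O)NCc2ccncc2)cc1` has not yet been measured. It differs from compound 2 in one place: amino in place of benzyl(methyl)amino on a sulfonyl sulfur. Among the compounds with values here, no measured pair shows this change, so its size is open. The expectation is a step in the direction of a higher number, clearly beyond the scatter, because the low number of compound 2 23 nM stands alone among the three. Compound 4 is therefore estimated at 2000 nM, within 200 nM to 20000 nM, meaning an expected step of an 87-fold higher number from compound 2 to compound 4 (1.94 log units; beyond the scatter).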

Compound 4, half-maximal effective concentration: 14300 nM
Compound 4: the middle estimate sits 7.2-fold (0.85 log units) below what was measured, and the stated range covers the measured number.
By their numbers in this assay, from the lowest: compound 2; then compounds 3 and 4 (each within the scatter of the next); then compound 1.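

In this assay, the group on the sulfonyl sulfur proves decisive: amino in place of benzyl(methyl)amino gives a 620-fold higher number from compound 2 to compound 4 (2.79 log units; beyond the scatter). The low number of compound 2 is therefore not retained with amino alone on the sulfonyl sulfur. Nothing available explains the size of this step.

As far as these compounds go, it remains open whether the aromatic ring or the methyl of the departing group accounts for the step. Benzylamino or methylamino on the sulfonyl sulfur would separate these two parts.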